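Retinoid-like dienones: from a fluorophenyl to a cyanophenyl end

This account rests on a few compounds, and the source may have more. Where it says the series, first, only, none or still open, it means among the compounds named here.

Of the compounds shown here, three sharing one core have been measured in a functional assay on LNCaP cells (Homo sapiens) for cytotoxicity, read by MTT assay, with a stated time of 72 h; a lower number here means a stronger inhibitor, a higher number a weaker inhibitor. Compound 1 `CC1=C(/C=C/C(=O)/C=C/c2cccc(C(F)(F)F)c2)C(C)(C)CCC1O` gives 740 nM. Compound 2 `CC1=C(/C=C/C(=O)/C=C/c2ccccc2F)C(C)(C)CCC1O` gives 2900 nM, and compound 3 `CC1=C(/C=C/C(=O)/C=C/c2ccc(F)cc2)C(C)(C)CCC1O` gives 3900 nM, the highest number of the three; its nearest neighbour is compound 2, while compound 1 lies furthest from it. For the measured compounds named here, the one measured step that bears on the new compound is a 1.3-fold higher number from compound 2 to compound 3 (0.13 log units; within the scatter), which moves a fluorine around the phenyl ring and shows no change beyond the scatter.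

Compound 4 `CC1=C(/C=C/C(=O)/C=C/c2cccc(C#N)c2)C(C)(C)CCC1O` differs from compound 3 as follows: 3-cyanophenyl in place of 4-fluorophenyl on a double-bonded chain carbon bound to a double-bonded chain carbon. Going by the values given here, no measured step covers this exchange. What the data show is that compound 1, with a 3-trifluoromethylphenyl, has a clearly lower number than compound 3, whereas the two fluorophenyl compounds sit close to each other. Because of the value 740 nM of compound 1, a substituent in the 3-position appears able to lower the number, but a nitrile is not a trifluoromethyl, so only a moderate step is expected.

For compound 4 a number of 1800 nM in this assay is expected, with a range from 700 nM to 4500 nM. The expected step of a 2.2-fold lower number from compound 3 to compound 4 (0.34 log units; beyond the scatter) is thus towards a lower number, of modest size.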

Compound 4, half-maximal inhibitory concentration: 1800 nM
Compound 4: the middle estimate sits on the measured number at the digits printed; measured number inside the range.
By their numbers in this assay, from the lowest: compound 1; then compounds 4, 2 and 3 (each within the scatter of the next, the first and the last beyond it).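

In this assay, the 3-cyanophenyl on a double-bonded chain carbon gives a modest move away from the 4-fluorophenyl (a 2.2-fold lower number from compound 3 to compound 4 (0.34 log units; beyond the scatter)), yet it cannot be told apart from the 2-fluorophenyl (a 1.6-fold lower number from compound 2 to compound 4 (0.21 log units; within the scatter)). Compound 4 therefore separates from only one of the two fluorophenyl compounds, and the size of this exchange depends on which of them serves as the reference. The exchange on an aromatic carbon adds what the earlier compounds could not show, that cyano and trifluoromethyl at the same place are not equivalent here (a 2.4-fold higher number from compound 1 to compound 4 (0.39 log units; beyond the scatter)), although nothing available explains this difference or any other among the four compounds.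

The compounds shown leave open how a 3-fluorophenyl would compare, which would separate the effect of the group from that of its place on the ring. They also leave open how a carboxylic acid, an aminomethyl group or a methoxy group on that same aromatic carbon would read in this assay, and so whether the trifluoromethyl of compound 1 stands apart or belongs to a wider set of groups.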